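Changing the Group on the Carbonyl Carbon

The source may report more compounds than this note shows. Statements on the series, on what has been measured and on what is new or still open speak of the compounds shown alone.

Three measured compounds share a core and differ only in the group attached to a carbonyl carbon. In a functional assay (trachea) with Rattus norvegicus as the target (on this read-out higher numbers stand for higher potency (the scale is a negative logarithm) and lower numbers for lower potency), compound 1 `COc1ccc(C(=O)c2ccc3c(c2)C(n2ccccc2=O)=CC(C)(C)O3)cc1` gives 5.72, compound 2 `CC1(C)C=C(n2ccccc2=O)c2cc(C(=O)c3ccco3)ccc2O1` gives 5.92, and compound 3 `CC1(C)C=C(n2ccccc2=O)c2cc(C(=O)c3ccc([N+](=O)[O-])cc3)ccc2O1` gives 6.09, the highest of the three numbers, though its gap to compound 2 lies within the scatter and only its gap to compound 1 lies beyond it. Compound 4 `CC1(C)C=C(n2ccccc2=O)c2cc(C(=O)c3c(F)cccc3F)ccc2O1` carries 2,6-difluorophenyl in place of 4-nitrophenyl on a carbonyl carbon. Going by the values given here, the steps that bear on this exchange were all small: a number 0.20 log units higher from compound 1 to compound 2 (within the scatter), a number 0.17 log units higher from compound 2 to compound 3 (within the scatter) and a number 0.37 log units higher from compound 1 to compound 3 (beyond the scatter). Swapping the group on the carbonyl carbon has so far moved this assay little, so a step of a number 0.19 log units lower from compound 3 to compound 4 (within the scatter) is expected, not beyond the scatter. Compound 4 is estimated at 5.9, between 5.5 and 6.3.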

Compound 4, logarithm of the reciprocal of the active concentration, log(1/C): 5.99
For compound 4 the middle estimate is 0.09 log units below the measured one; measured number inside the range.
By their numbers in this assay, from the lowest: compounds 1, 2, 4 and 3 (each within the scatter of the next, the first and the last beyond it).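

In this assay, going by these compounds alone, 2,6-difluorophenyl on the carbonyl carbon gives a number 0.10 log units lower from compound 3 to compound 4 (within the scatter) and a number 0.07 log units higher from compound 2 to compound 4 (within the scatter) and a number 0.27 log units higher from compound 1 to compound 4 (within the scatter) so compound 4 separates from none of the earlier compounds. The 4-nitrophenyl group counts hydrogen-bond acceptors and 2,6-difluorophenyl counts none, yet this exchange stays within the scatter. No measurement here offers a reason for this.

All four groups on this carbonyl carbon are aromatic rings. As far as these compounds go, whether an amine or a longer carbon chain in that place would keep the number in the same range remains open.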